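This account rests on a few compounds, and the source may have more. Where it says the series, first, only, none or still open, it means among the compounds named here.

Among the three compounds measured in an in vitro assay on BTI-TN-5B1-4 cells for inhibition of Amine oxidase [flavin-containing] B (Homo sapiens), read by fluorescence (a higher number here means a weaker inhibitor, a lower number a stronger inhibitor), compound 3 `CC(C)CNC(=O)c1cc2ccc(OCc3ccccc3)cc2oc1=O`, which gives 9590 nM, holds the second highest number. Its nearest neighbour is compound 2 `O=C(NC1CCCCC1)c1cc2ccc(OCc3ccccc3)cc2oc1=O`, which gives 64500 nM in this assay; the furthest is compound 1 `COc1ccc(NC(=O)c2cc3ccccc3oc2=O)cc1OC`, which gives 860 nM. The only single-point step among these three is a 6.7-fold lower number from compound 2 to compound 3 (0.83 log units; beyond the scatter), a swap of one alkyl group for another on the amide nitrogen.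

Compound 4 `COc1ccc(NC(=O)c2cc3ccc(OCc4ccccc4)cc3oc2=O)cc1OC` is not yet measured. It arises from compound 3 by 3,4-dimethoxyphenyl in place of isobutyl on an amide-type nitrogen. Among the measured compounds shown here, no measured step bears directly on an alkyl-to-aryl exchange on that nitrogen; the one step available, a 6.7-fold lower number from compound 2 to compound 3 (0.83 log units; beyond the scatter), only shows that this position moves the number by a modest amount. What the values do show is that compound 1, whose structure carries the same 3,4-dimethoxyphenyl on its amide nitrogen but a different core, gives 860 nM, the lowest number of the set.

For the measured compounds named here, on that basis compound 4 is expected to give a lower number than compound 3, a step estimated at a 6.4-fold lower number from compound 3 to compound 4 (0.81 log units; beyond the scatter) in this assay, with real uncertainty given that no measured pair matches the change. The estimate for compound 4 is 1500 nM, within a range of 300 nM to 8000 nM.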

Compound 4, half-maximal inhibitory concentration: 4390 nM
The estimate for compound 4 lay 2.9-fold (0.47 log units) below the measured number; the range from low to high includes it.
By their numbers in this assay, from the lowest: compound 1; then compound 4; then compound 3; then compound 2.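

In this assay the 3,4-dimethoxyphenyl group on the amide-type nitrogen brings a 2.2-fold lower number from compound 3 to compound 4 (0.34 log units; beyond the scatter) and a 15-fold lower number from compound 2 to compound 4 (1.17 log units; beyond the scatter) on the shared core, so this aromatic group now has the lowest number of the three groups seen at this position on that core, with both steps beyond the scatter. With that same group held on the nitrogen, benzyloxy in place of hydrogen on an aromatic carbon gives a 5.1-fold higher number from compound 1 to compound 4 (0.71 log units; beyond the scatter) and so shows that the low number of compound 1 does not carry over intact to the benzyloxy-bearing core, which means the group on the nitrogen does not set the number alone. Nothing available explains why either change moves the number as it does.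

The compounds shown leave open whether the step to compound 4 comes from the aromatic ring itself or from its two methoxy groups, a question that a plain phenyl, or a ring carrying an amine or a carboxylic acid, would address. They also leave open whether benzyloxy in place of hydrogen would shift the number to the same extent with isobutyl or cyclohexyl on the nitrogen.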